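Shortening the chain on the core: from propyl to ethyl

The source may hold more compounds than are shown below. What is called first, only, known or untested is meant among the compounds shown, and "the series" means these compounds.

Of the compounds shown here, two have been measured in an assay on CHO cells for displacement of a labelled ligand from adenosine receptor A3 (Homo sapiens), read by scintillation counting, with a stated time of 3 h; a higher number here means a weaker inhibitor, a lower number a stronger inhibitor. Compound 1 `CCn1c(-c2ccccc2)nc2c(NC3CCC3)ncnc21` gives 84 nM. Compound 2 `CCCn1c(-c2ccccc2)nc2c(NC3CCOC3)ncnc21` gives 2810 nM, the higher of the two numbers, and its distance from compound 1 lies beyond the usual scatter. For the measured compounds named here, the two differ in more than one place, so no single step between them can be read off.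

Compound 3 `CCn1c(-c2ccccc2)nc2c(NC3CCOC3)ncnc21` is reached from compound 2 by one change, (hydrogen in place of methyl on a saturated chain carbon, two bonds along the chain from an aromatic nitrogen). Compound 3 thus carries the ethyl chain of compound 1 together with the ring of compound 2. Going by the values given here, no measured pair shows this change by itself. Because compound 1, with the same ethyl chain, gives 84 nM, a modest move toward lower numbers is expected, with the step from compound 2 to compound 3 estimated as a 2.3-fold lower number from compound 2 to compound 3 (0.37 log units; beyond the scatter). For compound 3 the expected value in this assay is 1200 nM, within a range from 300 nM to 5000 nM.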

Compound 3, inhibition constant: 1660 nM
Compound 3: middle estimate off by 1.4-fold (0.14 log units), on the low side; the measured number falls inside the stated range.
By their numbers in this assay, from the lowest: compound 1; then compounds 3 and 2 (each within the scatter of the next).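

In this assay, shortening the chain on the core from propyl to ethyl gives a 1.7-fold lower number from compound 2 to compound 3 (0.23 log units; within the scatter) and so, with oxolan-3-yl on the nitrogen, this change at this position cannot be told apart from repeat-to-repeat variation. For the compounds shown here, compound 3 also provides the first comparison with compound 1 that differs in only one place: oxolan-3-yl in place of cyclobutyl on a nitrogen on an aromatic ring gives a 20-fold higher number from compound 1 to compound 3 (1.30 log units; beyond the scatter) and is the only step of the two that lies beyond the scatter. Nothing available here explains either step.

Going by these compounds, whether propyl to ethyl would read the same with cyclobutyl on that nitrogen remains open. Also open, on these data alone, is what a longer chain such as butyl, or a cyclopentyl group on that nitrogen, would give.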